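The source may hold more compounds than are shown below. What is called first, only, known or untested is meant among the compounds shown, and "the series" means these compounds.

Compound 1 `O=C(Nc1cccc(-n2cc(-c3ccncc3)c(-c3ccc(Cl)c(O)c3)n2)c1)Nc1ccc(Cl)c(Cl)c1`, compound 2 `O=C(Nc1cccc(-n2cc(-c3ccncc3)c(-c3ccc(Cl)c(O)c3)n2)c1)Nc1cc(C(F)(F)F)cc(C(F)(F)F)c1` and compound 3 `COc1cc(-c2nn(-c3cccc(NC(=O)Nc4ccc(Cl)c(C(F)(F)F)c4)c3)cc2-c2ccncc2)ccc1Cl` share one core and differ only in the aryl urea end. In a functional assay on CCRF-CEM cells (Homo sapiens) for inhibition, read by sulforhodamine B assay, with a stated time of 48 h (on this read-out lower numbers stand for stronger inhibition of growth and higher numbers for weaker inhibition of growth), compound 1 gives only a limit, > 32500 nM. Compound 3 likewise gives only a limit there, > 32500 nM. Going by the values given here, compound 2 gives 6780 nM, the one number among the three. The remainder of the picture is the limit of > 32500 nM in this assay, at which 2 of the 3 values shown sit. Compound 4 `O=C(Nc1cccc(-n2cc(-c3ccncc3)c(-c3ccc(Cl)c(O)c3)n2)c1)Nc1cccc(C(F)(F)F)c1` differs from compound 2 by hydrogen in place of trifluoromethyl on an aromatic carbon. No single-site comparison among the measured compounds is available, so the change is expected to weaken growth inhibition, a step of a 2.7-fold higher number from compound 2 to compound 4 (0.42 log units; beyond the scatter) that could exceed the scatter. Compound 4 is therefore estimated at 18000 nM, with a range from 6000 nM to 40000 nM in this assay.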

Compound 4, concentration for total growth inhibition: > 32500 nM
Compound 4: no number, only a limit; the forecaster's own chance of this, stated with the estimate: 40%; at least 1.8-fold (0.25 log units) between middle value and limit.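

In this assay compound 4 gives only a limit, > 32500 nM. Hydrogen in place of trifluoromethyl on this aromatic carbon gives an at least 4.7-fold higher number from compound 2 to compound 4 (0.68 log units; beyond the scatter), the first single-site reading at this position, and only one of the compounds shown still has a number: the limit of > 32500 nM in this assay, at which 3 of the 4 values shown sit. The step from compound 1 to compound 4 cannot be read, since both values are limits. As far as these compounds go, how far the true value of compound 4 lies past its limit remains open. So does whether an amine or a nitrile on this carbon would restore growth inhibition.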